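The source may hold more compounds than are shown below. What is called first, only, known or untested is meant among the compounds shown, and "the series" means these compounds.

Compound 1 `Cc1cc(C)c(NC(=O)N(Cc2ccc(-c3cc[nH]n3)cc2)C2CCCCCC2)c(C)c1` and compound 2 `Cc1cc(C)c(NC(=O)N(Cc2cccc(-c3cc[nH]n3)c2)C2CCCCCC2)c(C)c1` share the same atoms; how their two cores differ is not broken down here. In an assay on microsomes from intestine for inhibition of acyl-CoA:cholesterol acyltransferase (Oryctolagus cuniculus) (a higher number here means a weaker inhibitor, a lower number a stronger inhibitor), compound 1 gives 52 nM, and compound 2 gives 65 nM. Compound 3 `Cc1cc(C)c(NC(=O)N(Cc2ccc(-c3cn[nH]c3)cc2)C2CCCCCC2)c(C)c1` carries 1H-pyrazol-4-yl in place of 1H-pyrazol-3-yl on an aromatic carbon, and in this assay compound 3 gives 270 nM, so that a 5.2-fold higher number from compound 1 to compound 3 (0.72 log units; beyond the scatter). Going by the values given here, compound 4 `Cc1cc(C)c(NC(=O)N(Cc2cccc(-c3cn[nH]c3)c2)C2CCCCCC2)c(C)c1` carries 1H-pyrazol-4-yl in place of 1H-pyrazol-3-yl on an aromatic carbon; this is the same kind of change as the one from compound 1 to compound 3, though the place differs, being meta to a large group rather than para to it. The step from compound 2 to compound 4 is expected to be a 4.6-fold higher number from compound 2 to compound 4 (0.66 log units; beyond the scatter), close to the step seen from compound 1 to compound 3 because a 5.2-fold higher number from compound 1 to compound 3 (0.72 log units; beyond the scatter). Compound 4 is therefore estimated at 300 nM, between 120 nM and 750 nM.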

Compound 4, half-maximal inhibitory concentration: 38 nM
Estimate against measurement, compound 4: 7.9-fold (0.90 log units) above; the measured number lies below the stated range.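

Swapping 1H-pyrazol-3-yl for 1H-pyrazol-4-yl gives a 1.7-fold lower number from compound 2 to compound 4 (0.23 log units; within the scatter) in this assay and so shows no loss like the one seen on the core of compound 1. The same swap therefore does not carry over as a fixed shift from one core to the other: the same change on two cores in this assay, a 5.2-fold higher number (0.72 log units; beyond the scatter) from compound 1 to compound 3 and a 1.7-fold lower number (0.23 log units; within the scatter) from compound 2 to compound 4, 8.9-fold (0.95 log units) apart, beyond the scatter of two such steps. Going by these compounds alone, this shows that the outcome of the swap depends on the core, but with only one pair per core it does not show why, or what the swap would do on a third core.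

The compounds shown leave open how an imidazole, a carboxylic acid or an amine would behave in place of the pyrazole on each core. They also leave open whether such groups would separate the two cores in the same way.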